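This account rests on a few compounds, and the source may have more. Where it says the series, first, only, none or still open, it means among the compounds named here.

Compound 1 `C[C@H]1C=C2C=C[C@H](C)[C@H](CC[C@@H]3C[C@@H](O)CC(=O)O3)C2[C@@H](OC(=O)C2CC2)C1` gives 38.6 nM in an assay for inhibition of 3-hydroxy-3-methylglutaryl-coenzyme A reductase (Rattus norvegicus); a lower number here means a stronger inhibitor, a higher number a weaker inhibitor.
Compound 2 `CC(C)CC(=O)O[C@H]1C[C@@H](C)C=C2C=C[C@H](C)[C@H](CC[C@@H]3C[C@@H](O)CC(=O)O3)C21` gives 5.4 nM.
Compound 3 `CC(CC(=O)O[C@H]1C[C@@H](C)C=C2C=C[C@H](C)[C@H](CC[C@@H]3C[C@@H](O)CC(=O)O3)C21)C(F)(F)F` gives 3.5 nM.

Among the three measured compounds, compound 3 carries the lowest number, but the step of a 1.5-fold lower number from compound 2 to compound 3 (0.19 log units; within the scatter) is only a small one, so the two cannot be ranked against each other; only compound 1 stands clearly apart, with an 11-fold lower number from compound 1 to compound 3 (1.04 log units; beyond the scatter). Compound 4 `C[C@H]1C=C2C=C[C@H](C)[C@H](CC[C@@H]3C[C@@H](O)CC(=O)O3)C2[C@@H](OC(=O)C(C)(C)C)C1` has not yet been measured. It differs from compound 3 by tert-butyl in place of 2-(trifluoromethyl)propyl on a carbonyl carbon. Within the data shown here, two measured steps bear on this exchange, since both alter the group on the carbonyl carbon: a 7.1-fold lower number from compound 1 to compound 2 (0.85 log units; beyond the scatter) and an 11-fold lower number from compound 1 to compound 3 (1.04 log units; beyond the scatter). Both show that leaving cyclopropyl for isobutyl or 2-(trifluoromethyl)propyl lowered the number markedly, while a 1.5-fold lower number from compound 2 to compound 3 (0.19 log units; within the scatter) shows that the trifluoromethyl for methyl exchange within the chain mattered little. Compound 4 gives up the chain entirely for tert-butyl, a group of four carbons without the chain. The account therefore expects a step upward in this assay, larger than the scatter, though smaller than the return to cyclopropyl: the expected step is a 4.0-fold higher number from compound 3 to compound 4 (0.60 log units; beyond the scatter). Compound 4 is estimated at 14 nM, within a range of 5 nM to 40 nM.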

Compound 4, half-maximal inhibitory concentration: 2.7 nM
Estimate against measurement, compound 4: 5.2-fold (0.71 log units) above; the measured number lies below the stated range.
By their numbers in this assay, from the lowest: compounds 4, 3 and 2 (each within the scatter of the next); then compound 1.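

In this assay, tert-butyl on this carbonyl carbon cannot be told apart from 2-(trifluoromethyl)propyl (a 1.3-fold lower number from compound 3 to compound 4 (0.11 log units; within the scatter)) or from isobutyl (a 2.0-fold lower number from compound 2 to compound 4 (0.30 log units; within the scatter)). The chain of those two groups and the fluorine of the first are therefore not needed to keep the number in this range. Cyclopropyl, the only ring among the four groups, remains the one exchange that clearly stands apart, now also against tert-butyl (a 14-fold lower number from compound 1 to compound 4 (1.16 log units; beyond the scatter)), and no measurement at hand explains this.

The compounds shown leave open whether a longer chain, a phenyl group or a cyclohexyl group on this carbonyl carbon would stay with the three close compounds. Nor do they tell whether cyclobutyl would fall with cyclopropyl or with tert-butyl.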